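Swapping a Chloro for Dimethylamino on the Hydrazone Ring

A few compounds are considered here, and "the series" means these few. Any claim that something is new, unique, unknown or untested is made for them only; others in the source may bear on it.

Measured so far:
compound 1 `O=C(N/N=C/c1cccc(F)c1)c1cccnc1Nc1cccc(C(F)(F)F)c1` gives 29.8%
compound 2 `O=C(N/N=C/c1ccc(Cl)cc1)c1cccnc1Nc1cccc(C(F)(F)F)c1` gives 43.7%

These two compounds were tested in a functional assay on the whole organism (strain Wistar) for inhibition, with Rattus norvegicus as the target, read by paw edema, with a stated time of 4 h, at a dose of 10 mg/kg by the intraperitoneal route; a lower number here means less inhibition, a higher number more inhibition at the dose given (going by the name of the read-out). For the measured compounds named here, compound 2 stands highest of the two, and the only measured step, a number 13.9 percentage points higher from compound 1 to compound 2 (beyond the scatter), lies beyond the scatter. Compound 3 `CN(C)c1ccc(/C=N/NC(=O)c2cccnc2Nc2cccc(C(F)(F)F)c2)cc1` differs from compound 2 in one place: dimethylamino in place of chloro on an aromatic carbon. Going by the values given here, no measured step covers a dimethylamino group, so the one step available does not bear directly on this change; it only shows that a swap on this ring can move the read-out by a modest amount. With nothing pointing in either direction, no change beyond the scatter is expected, and the estimated step is a number 3.7 percentage points lower from compound 2 to compound 3 (within the scatter). Compound 3 is therefore expected to give about 40%, with a range from 25% to 55%.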

Compound 3, a percentage reported as inhibition, in the whole organism at one dose (the size of the read-out at that dose, not a potency): 28.2%
The estimate for compound 3 lay 11.8 percentage points above the measured number; the measured number falls inside the stated range.
By their numbers in this assay, from the lowest: compounds 3 and 1 (each within the scatter of the next); then compound 2.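

In this assay, dimethylamino in place of chloro gives a number 15.5 percentage points lower from compound 2 to compound 3 (beyond the scatter) with the rest of the molecule unchanged, so the group at this place on the aromatic ring can shift the read-out. The 4-(dimethylamino)phenyl and 3-fluorophenyl versions read alike, with a number 1.6 percentage points lower from compound 1 to compound 3 (within the scatter) as the step between them, which leaves compound 2 with its 4-chlorophenyl alone at the top of these three compounds. Nothing available explains why chloro and dimethylamino differ here.

The compounds shown leave open whether the higher number belongs to chloro in particular or would also appear with another halogen, such as bromo. They also leave open how a smaller amine or a methoxy group at this place would compare with compound 2 and compound 3.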